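A few compounds are considered here, and "the series" means these few. Any claim that something is new, unique, unknown or untested is made for them only; others in the source may bear on it.

Measured so far:
compound 1 `CCOC(=O)[C@@H](N)CCC(=O)NCCSC(=O)C(C)(C)C`: 8.9
compound 2 `CCCOC(=O)[C@@H](N)CCC(=O)NCCSC(C)=O`: 8.8

In a physicochemical assay for acid dissociation, using potentiometric titration, at pH 2, compound 2 gives 8.8, within the scatter of compound 1. Compound 3 `CCOC(=O)[C@@H](N)CCC(=O)NCCSC(C)=O` is not yet measured. It differs from compound 2 in one place: hydrogen in place of methyl on a saturated chain carbon, two bonds along the chain from an oxygen next to a carbonyl group. This is hydrogen in place of methyl on a saturated chain carbon, two bonds along the chain from an oxygen next to a carbonyl group; cut one bond further out, the same difference reads propoxy to ethoxy.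

Within the data shown here, no measured pair differs in one place only, so the size of this step has no direct precedent. The nearest guide is compound 1 at 8.9, which also carries ethoxy. In this assay no change beyond the scatter is expected, and the estimated step is no change at the digits printed from compound 2 to compound 3 (within the scatter). For compound 3 the expected value is 8.8, with an estimated range of 8.5 to 9.1.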

Compound 3, acid dissociation constant: 8.94
Compound 3: the middle estimate sits 0.14 log units below what was measured; low and high end bracket the measured number.
By their numbers in this assay, from the lowest: compounds 2, 1 and 3 (each within the scatter of the next).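

In this assay, the series now has its first steps at a single place: propoxy to ethoxy gives a number 0.14 log units higher from compound 2 to compound 3 (within the scatter), and methyl in place of tert-butyl on a carbonyl carbon gives a number 0.04 log units higher from compound 1 to compound 3 (within the scatter). Neither change, one on a saturated chain carbon and one on a carbonyl carbon, carries the read-out beyond the scatter, so both places appear tolerant of these particular swaps within these three compounds. Nothing available explains this absence of a measurable step.

Still open, from the compounds shown here alone, is whether a longer chain or a branched isopropyl group at the first place, or a carboxylic acid in place of the ester, would also leave the read-out within the scatter. A phenyl group in place of methyl on the carbonyl carbon is likewise untested by the compounds shown here.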